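Removing a ketone from the amide side chain: compound 4

This account rests on a few compounds, and the source may have more. Where it says the series, first, only, none or still open, it means among the compounds named here.

Of the compounds shown here, three that share a common core have been measured in an assay on HEK293 cells for displacement of a labelled ligand from Melanocortin receptor 4 (Homo sapiens); on this read-out lower numbers stand for stronger inhibition and higher numbers for weaker inhibition. Compound 1 `CC(C)C[C@H](N)c1cc(C(F)(F)F)ccc1N1CCN(C(=O)COc2ccc(O)cc2)CC1` gives 4600 nM. Compound 2 `COc1ccc(CC(C)C(=O)N2CCN(c3ccc(C(F)(F)F)cc3[C@@H](N)CC(C)C)CC2)cc1` gives 120 nM. Compound 3 `CC(C)C[C@H](N)c1cc(C(F)(F)F)ccc1N1CCN(C(=O)CC(C)C(=O)c2ccc(Cl)cc2)CC1` gives 1100 nM, the second highest number of the three: its nearest neighbour is compound 1, with a 4.2-fold lower number from compound 1 to compound 3 (0.62 log units; beyond the scatter) separating them, and its furthest is compound 2, with a 9.2-fold higher number from compound 2 to compound 3 (0.96 log units; beyond the scatter).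

Compound 4 `CC(C)C[C@H](N)c1cc(C(F)(F)F)ccc1N1CCN(C(=O)[C@H](C)Cc2ccc(Cl)cc2)CC1` has not yet been measured. It differs from compound 3 in one place: 1-(4-chlorobenzyl)ethyl in place of 2-((4-chlorophenyl)carbonyl)propyl on a carbonyl carbon. The group that enters is the same kind of side chain as in compound 2, with a chlorine in place of the methoxy group of compound 2 and without the carbonyl that sits in the chain of compound 3.

For the measured compounds named here, the step that bears most directly on this change is the one from compound 2 to compound 3, which was a 9.2-fold higher number from compound 2 to compound 3 (0.96 log units; beyond the scatter), and compound 4 essentially undoes that chain alteration. The step of a 38-fold lower number from compound 1 to compound 2 (1.58 log units; beyond the scatter) also shows that a benzyl-ethyl side chain on the carbonyl carbon goes with a much lower number in this assay. Compound 4 is therefore expected to return toward the region of compound 2, with an expected step of a 7.3-fold lower number from compound 3 to compound 4 (0.87 log units; beyond the scatter). The estimate for compound 4 is 150 nM, within a range of 50 nM to 500 nM.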

Compound 4, inhibition constant: 31 nM
Compound 4: middle estimate off by 4.8-fold (0.68 log units), on the high side, and the stated range ends above it.
By their numbers in this assay, from the lowest: compound 4; then compound 2; then compound 3; then compound 1.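

In this assay, the 1-(4-chlorobenzyl)ethyl group on the carbonyl carbon gives a 35-fold lower number from compound 3 to compound 4 (1.55 log units; beyond the scatter), so this chain without the carbonyl of 2-((4-chlorophenyl)carbonyl)propyl lies far lower than compound 3 and not merely back in the region of compound 2. The earlier steps shown here all altered the chain itself, whereas a 3.9-fold lower number from compound 2 to compound 4 (0.59 log units; beyond the scatter) keeps the chain and shows, beyond the scatter, that the number still moves when chlorine replaces the methoxy group, although compound 4 also carries a defined stereocentre in this chain that compound 2 does not. With a 150-fold lower number from compound 1 to compound 4 (2.17 log units; beyond the scatter), the largest step in the set, compound 4 has the lowest number of the four, and its steps to all three others are beyond the scatter.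

Nothing among the data shown accounts for any of these steps. The compounds shown leave open how much of the step from the methoxy group to chlorine belongs to the chlorine and how much to the defined stereocentre, how the opposite configuration of that carbon would read, and whether a bromine, a nitrile or a trifluoromethyl group in place of the chlorine would give a lower or a higher number.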